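A Benzoate Swap Followed in Breast Cancer Cell Growth

A few compounds are considered here, and "the series" means these few. Any claim that something is new, unique, unknown or untested is made for them only; others in the source may bear on it.

Of the compounds shown here, three have been measured in a functional assay on MDA-MB-231 cells (Homo sapiens) for antiproliferative activity, read by MTT assay, with a stated time of 72 h; on this read-out higher numbers stand for weaker inhibition and lower numbers for stronger inhibition. Compound 1 `CC1=CCC2C(CC[C@@]2(C)O)C(C)(C)C1CC[C@@H]1[C@@]2(C)CC[C@@H](O)C(C)(C)O[C@@H]2CC[C@]1(C)O` gives only a limit there, > 50000 nM. Compound 2 `CC(=O)O[C@H]1CC[C@]2(C)[C@H](CC[C@@](C)(O)[C@H]2CC[C@@H]2C(C)=CC[C@H]3[C@H](CC[C@]3(C)OC(C)=O)C2(C)C)OC1(C)C` gives 26200 nM in this assay. Compound 3 `CC1=CC[C@H]2[C@H](CC[C@]2(C)O)C(C)(C)[C@@H]1CC[C@H]1[C@]2(C)CC[C@H](OC(=O)c3ccc(Cl)cc3)C(C)(C)O[C@H]2CC[C@@]1(C)O` gives 10300 nM, the lowest of the two numbers, and the gap to compound 2 lies beyond the usual scatter. The unmeasured compound 4 `CC1=CC[C@H]2[C@H](CC[C@]2(C)O)C(C)(C)[C@@H]1CC[C@H]1[C@]2(C)CC[C@H](OC(=O)c3cccc(C(F)(F)F)c3)C(C)(C)O[C@H]2CC[C@@]1(C)O` differs from compound 3 in one place: 3-(trifluoromethyl)phenyl in place of 4-chlorophenyl on a carbonyl carbon. For the measured compounds named here, no measured pair shows a change of this kind, so the writer expects a step that stays close to the scatter, with no clear direction, rather than a marked shift. The step of a 1.1-fold lower number from compound 3 to compound 4 (0.06 log units; within the scatter) is thus expected to be small. Compound 4 is estimated at 9000 nM, within a likely range from 4000 nM to 25000 nM.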

Compound 4, half-maximal inhibitory concentration: 36300 nM
Compound 4: the middle estimate sits 4.0-fold (0.61 log units) below what was measured; measured number above the stated range.
By their numbers in this assay, from the lowest: compound 3; then compounds 2 and 4 (each within the scatter of the next). At a limit, above all of these: compound 1.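

The position on the shared core that carries the aryl carbonyl group is not indifferent to which aryl group it holds: in this assay, 3-(trifluoromethyl)phenyl in place of 4-chlorophenyl on a carbonyl carbon gives a 3.5-fold higher number from compound 3 to compound 4 (0.55 log units; beyond the scatter). For the compounds shown here, this is the first change in one place that can be read here, and it moves the number beyond the scatter. Nothing at hand accounts for the direction of this step. As far as these compounds go, whether a 4-(trifluoromethyl)phenyl group, a 3-chlorophenyl group or a pyridine ring on the same carbonyl carbon would keep the number of compound 3 stays open.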